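Amino to dimethylamino on the ethyl chain: series notes

The source may hold more compounds than are shown below. What is called first, only, known or untested is meant among the compounds shown, and "the series" means these compounds.

Measured so far in an assay on HeLa cells for binding affinity to 5-hydroxytryptamine receptor 6 (Homo sapiens); a lower number here means a stronger inhibitor, a higher number a weaker inhibitor:
- compound 1, `NCCn1cc(S(=O)(=O)c2ccccc2)c2ccc(Cl)cc21`: 141 nM
- compound 2, `NCCn1cc(S(=O)(=O)c2ccccc2)c2cc(F)ccc21`: 27 nM
- compound 3, `CN(C)CCn1cc(S(=O)(=O)c2ccccc2)c2ccc(Cl)cc21`: 42 nM

Compound 1 and compound 2 share the sulfonyl-indole framework with a 2-aminoethyl chain on the aromatic nitrogen but differ in the halogen and its position on the bicyclic ring; that difference between the two cores is not broken down here. Compound 2 carries the lowest number of the three, and its gap to compound 1 lies beyond the scatter, while its gap to compound 3 does not.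

One change is seen once with a measurement: dimethylamino in place of amino on a saturated chain carbon, two bonds along the chain from an aromatic nitrogen. This step, a 3.4-fold lower number from compound 1 to compound 3 (0.53 log units; beyond the scatter), is modest but lies beyond the scatter.

Compound 4, `CN(C)CCn1cc(S(=O)(=O)c2ccccc2)c2cc(F)ccc21`, is not yet measured. It differs from compound 2 in the same way: dimethylamino in place of amino on a saturated chain carbon, two bonds along the chain from an aromatic nitrogen. The place is the same in both pairs, so the change is the same, made on the other core.

The expectation for compound 4 rests on one step only, that from compound 1 to compound 3, a 3.4-fold lower number from compound 1 to compound 3 (0.53 log units; beyond the scatter), and on the value of compound 2, 27 nM. Whether the step carries over to the fluoro core cannot be checked against anything else in this set, so the range is kept wide. The step to compound 4 is estimated as a 2.7-fold lower number from compound 2 to compound 4 (0.43 log units; beyond the scatter) in this assay. Compound 4 is therefore expected near 10 nM, with a range from 4 nM to 25 nM.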

Compound 4, inhibition constant: 44 nM
Beside the measured number, compound 4's estimate is 4.4-fold (0.64 log units) below it; the measured number lies above the stated range.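

In this assay the new step, a 1.6-fold higher number from compound 2 to compound 4 (0.21 log units; within the scatter), leaves compound 4 not separable from compound 2, so dimethylamino in place of amino does not repeat on this core what it did on the core of compound 1, and the two readings of the same change differ: the same change on two cores in this assay, a 3.4-fold lower number (0.53 log units; beyond the scatter) from compound 1 to compound 3 and a 1.6-fold higher number (0.21 log units; within the scatter) from compound 2 to compound 4, 5.5-fold (0.74 log units) apart, beyond the scatter of two such steps. The change therefore does not carry over as a fixed step between these two cores, and a step read on one of them is a poor guide to the other in this series. This does not show why the two cores part, nor which of them is the more typical, for two pairs, each read once, cannot settle either question.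

The compounds shown leave open whether the identity of the halogen or its position on the ring decides the difference, as the two cores differ in both at once. Also open, as far as these compounds go, is how the step behaves on other cores, and how other chain ends, such as methylamino or diethylamino, or a longer chain such as 3-aminopropyl, would read on these two cores.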